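Trifluoromethoxy in Place of Isobutoxy at the Assay Limit

The source may hold more compounds than are shown below. What is called first, only, known or untested is meant among the compounds shown, and "the series" means these compounds.

Compound 3 (`CCOC(=O)c1c(-c2cccc(OCC(C)C)c2)[nH]c2cc(OC)ccc2c1=O`) was read in an ADME assay on Raji cells (Homo sapiens) for cytotoxicity, read by luminescence, with a stated time of 72 h (on this read-out lower numbers stand for an effect already at smaller amounts and higher numbers for an effect only at larger amounts of compound), together with compound 1 (`CCOC(=O)c1c(-c2cccc(-c3ccccc3)c2)[nH]c2cc(OC)ccc2c1=O`) and compound 2 (`CCOC(=O)c1c(-c2cccc(OC(C)C)c2)[nH]c2cc(OC)ccc2c1=O`). Compound 1 shows > 21500 nM as a limit and not a number. Compound 2 shows > 21500 nM and this is likewise a limit. Compound 3 shows > 21500 nM and this too is only a limit. The whole measured set therefore stands at a single mark (the limit of > 21500 nM in this assay, at which 3 of the 3 values shown sit). Compound 4 (`CCOC(=O)c1c(-c2cccc(OC(F)(F)F)c2)[nH]c2cc(OC)ccc2c1=O`) has trifluoromethyl in place of isobutyl on an oxygen on an aromatic ring. The nearest measured change is a step that the two limits leave unreadable from compound 2 to compound 3 with isobutyl in place of isopropyl on that oxygen, while a step that the two limits leave unreadable from compound 1 to compound 2 and a step that the two limits leave unreadable from compound 1 to compound 3 replace phenyl. None of these gives a size or a direction, so no step beyond the scatter is expected in this assay on this evidence. The expected change is a step that the limit leaves unreadable from compound 3 to compound 4 with neither direction favoured. Compound 4 is estimated at 25000 nM with an expected range from 12000 nM to 50000 nM and will probably be reported as a limit again.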

Compound 4, half-maximal effective concentration: > 21500 nM
Compound 4 ended at the assay's limit; the forecaster's own chance of this, stated with the estimate: 85%; the middle value does not contradict the limit.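

Among these compounds, no step from compound 1, compound 2 or compound 3 to compound 4 can be read, because all four compounds stand at a single mark: the limit of > 21500 nM in this assay, at which 4 of the 4 values shown sit. The compounds shown leave open whether exchanging these groups changes the half-maximal effective concentration at all, and in which direction.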